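Fluorinated ether in place of isopropyl ether: working expectation

The source may report more compounds than this note shows. Statements on the series, on what has been measured and on what is new or still open speak of the compounds shown alone.

Three analogues sharing one core have been measured in a functional assay on CHO cells with sphingosine 1-phosphate receptor 2 (Homo sapiens) as the target, read by GTPgammaS binding; a lower number here means that less compound is needed, a higher number that more compound is needed for the effect. Compound 1 `Cc1cc(-c2nc(-c3ccc(CCC(=O)O)cc3C)no2)ccc1OC(C)C` reaches only the assay limit, giving > 10000 nM. Compound 2 `COc1cc(-c2nc(-c3ccc(CCC(=O)O)cc3C)no2)ccc1OC(C)C` likewise returns a limit, > 10000 nM. Compound 3 `Cc1cc(CCC(=O)O)ccc1-c1noc(-c2ccc(OC(C)C)c(C#N)c2)n1` also sits at a limit, > 10000 nM. The steps among them, a step that the two limits leave unreadable from compound 1 to compound 2, a step that the two limits leave unreadable from compound 1 to compound 3 and a step that the two limits leave unreadable from compound 2 to compound 3, therefore carry no readable size; all that stands is the limit of > 10000 nM in this assay, at which 3 of the 3 values shown sit. Compound 3 thus stands nowhere above the floor of the series.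

Compound 4 `Cc1cc(CCC(=O)O)ccc1-c1noc(-c2ccc(OC(C(F)(F)F)C(F)(F)F)c(C#N)c2)n1` differs from compound 3 only by 2,2,2-trifluoro-1-(trifluoromethyl)ethyl in place of isopropyl on an oxygen on an aromatic ring. Among the measured compounds shown here, none of the measured steps touches this oxygen-bound group, so no direction can be read from them. For the measured compounds named here, the only bearing is that compound 3 and both neighbours are limits, which gives no foothold for a gain. Compound 4 is expected to stay at or near the limit, estimated at 10000 nM within 2000 nM to 30000 nM. The expected step is a number no higher from compound 3 to compound 4 (the limit leaves the size open), most likely again unreadable.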

Compound 4, half-maximal effective concentration: > 10000 nM
Compound 4 ended at the assay's limit (the forecaster's own chance of this, stated with the estimate: 70%); the middle value lies on the limit itself.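

In this assay, among the compounds shown here, compound 4 gives > 10000 nM, a limit and not a number, so no step between compound 3 and compound 4 can be read. The compounds shown leave open whether any change to the shared core gives a readable value in this assay.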